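The compounds below may be only part of what the source reports. "The series", "measured", "known", "first", "only" and "open" are said of these compounds alone.

Measured compounds:
- compound 1 `COc1cccc(Oc2ccc3cc(NC(=O)c4ccc(OC(C)=O)c(CC=C(C)C)c4)c(=O)oc3c2C)c1` — in a functional assay on SK-BR-3 cells (Homo sapiens) for antiproliferative activity (a higher number here means a weaker inhibitor, a lower number a stronger inhibitor), compound 1 gives 13700 nM
- compound 2 `COc1cccc(Oc2ccc3cc(NC(=O)c4ccc(O)c(CC=C(C)C)c4)c(=O)oc3c2C)c1` — in this assay compound 2 gives 33100 nM
- compound 3 `COc1ccc(Oc2ccc3cc(NC(=O)c4ccc(OC)c(-c5cccc(OC)c5)c4)c(=O)oc3c2C)cc1` — in this assay compound 3 reaches only a limit, > 100000 nM

Compound 1 holds the lowest of the two numbers that were actually obtained. Among the measured compounds shown here, its nearest neighbour is compound 2, and the only single-point step available, hydrogen in place of acetyl on an oxygen on an aromatic ring, shows a 2.4-fold higher number from compound 1 to compound 2 (0.38 log units; beyond the scatter). The third value is a limit of the assay and nothing more (the limit of > 100000 nM in this assay, at which 1 of the 3 values shown sits).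

Compound 4 `COc1ccc(Nc2ccc3cc(NC(=O)c4ccc(OC(C)=O)c(CC=C(C)C)c4)c(=O)oc3c2C)cc1` is the compound that has not yet been measured. Compared with compound 1 the change is (4-methoxyphenyl)amino in place of 3-methoxyphenoxy on an aromatic carbon. For the measured compounds named here, none of the measured steps touches this part of the core: the step from compound 1 to compound 2 concerns the acetyl on the other end of the molecule, and compound 3 differs from compound 1 in several places at once and gives only a limit, so it cannot be read as a single step.

Going by the values given here, with no directly comparable step, the expectation for compound 4 rests on compound 1 alone, and the estimate is a 1.1-fold higher number from compound 1 to compound 4 (0.04 log units; within the scatter), a change not expected to pass beyond the usual scatter. Compound 4 is therefore expected to give about 15000 nM, with a range from 5000 nM to 50000 nM.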

Compound 4, half-maximal inhibitory concentration: > 100000 nM
Compound 4 was reported as a limit; the forecaster's own chance of this, stated with the estimate: 10%; middle value at least 6.6-fold (0.82 log units) away from the limit.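

Among the compounds shown here, until now, the only readable step concerned the acetyl at the other end of the molecule, so nothing showed how the group on the aromatic carbon ortho to the methyl group affects the result. Putting (4-methoxyphenyl)amino in place of 3-methoxyphenoxy gives an at least 7.2-fold higher number from compound 1 to compound 4 (0.86 log units; beyond the scatter), which shows that this position is not indifferent to change in this assay, even though the two groups have the same count of heavy atoms and one six-membered aromatic ring each. The true size of the step remains unknown, since compound 4 gives only a limit, the second compound shown to do so: the limit of > 100000 nM in this assay, at which 2 of the 4 values shown sit.

This single change alters two things at once, as the linking oxygen gives way to a nitrogen carrying a hydrogen and the methoxy group moves to a different place on the outer ring, and the compounds shown cannot say which of these matters. A (3-methoxyphenyl)amino group at this position on the core of compound 1 would separate the two, while a smaller group such as a plain amine would show whether the outer ring is needed at all.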